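Changing the Aryl Group of Compound 3

A few compounds are considered here, and "the series" means these few. Any claim that something is new, unique, unknown or untested is made for them only; others in the source may bear on it.

Among the compounds with values here, in a functional assay on NCI-H520 cells (Homo sapiens) (on this read-out lower numbers stand for stronger inhibition of growth and higher numbers for weaker inhibition of growth), compound 3 `O=S(=O)(/C=C/c1ccc(F)cc1Cl)Cc1ccc(Nc2ncnc3ccccc23)cc1` gives 100000 nM, the higher of the two exact numbers so far. Compound 2 `O=S(=O)(/C=C/c1ccc(Cl)cc1Cl)Cc1ccc(Nc2ncnc3ccccc23)cc1` gives 12000 nM. For compound 1 `N#Cc1ccc(/C=C/S(=O)(=O)Cc2ccc(Nc3ncnc4ccccc34)cc2)cc1` the assay reports only a limit, > 100000 nM. Fluoro in place of chloro on an aromatic carbon gave an 8.3-fold higher number from compound 2 to compound 3 (0.92 log units; beyond the scatter). Replacing 4-cyanophenyl with 2,4-dichlorophenyl gave an at least 8.3-fold lower number from compound 1 to compound 2 (0.92 log units; beyond the scatter). Compound 4 `O=S(=O)(/C=C/c1ccc(C(F)(F)F)cc1F)Cc1ccc(Nc2ncnc3ccccc23)cc1` carries 2-fluoro-4-(trifluoromethyl)phenyl in place of 2-chloro-4-fluorophenyl (2-fluoro-4-(trifluoromethyl)phenyl in place of 2-chloro-4-fluorophenyl on a double-bonded chain carbon bound to a double-bonded chain carbon). These two modest steps show that this group can matter, but neither tests the new group, so only a small shift toward stronger inhibition is expected, a 1.7-fold lower number from compound 3 to compound 4 (0.22 log units; within the scatter). The estimate for compound 4 is 60000 nM, within an expected range of 12000 nM to 150000 nM.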

Compound 4, concentration for 50% growth inhibition: 100000 nM
Compound 4: the middle estimate sits 1.7-fold (0.22 log units) below what was measured; the measured number falls inside the stated range.
By their numbers in this assay, from the lowest: compound 2; then compounds 3 and 4 (each within the scatter of the next).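

2-fluoro-4-(trifluoromethyl)phenyl in place of 2-chloro-4-fluorophenyl gives no change at the digits printed from compound 3 to compound 4 (within the scatter), so these two groups cannot be told apart here. The other readable step is an 8.3-fold higher number from compound 2 to compound 4 (0.92 log units; beyond the scatter), which leaves 2,4-dichlorophenyl as the only group shown with a clearly lower number. Compound 1 carries only a limit: the limit of > 100000 nM in this assay, at which 1 of the 4 values shown sits. 2-fluoro-4-(trifluoromethyl)phenyl in place of 4-cyanophenyl therefore gives a number no higher from compound 1 to compound 4 (the limit leaves the size open), and the size of this step cannot be read.

Going by these compounds, it remains open whether the second chlorine of compound 2 is what matters, or whether 2,4-dibromophenyl would match it. On these data alone, how a phenyl ring bearing an amine or a carboxylic acid would behave at this place also remains open.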